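The compounds below may be only part of what the source reports. "The series", "measured", "known", "first", "only" and "open" are said of these compounds alone.

Series notes, single-concentration work in an in vitro assay on P815B cells for inhibition of Indoleamine 2,3-dioxygenase 1 (Mus musculus), tested at 20 uM; on this read-out lower numbers stand for less inhibition and higher numbers for more inhibition at the one concentration tested (going by the name of the read-out). Three compounds carry a result of some kind. Compound 1 `O=C(Cc1cccnc1)c1cc2cc(-c3ccccc3)ccc2[nH]1` is recorded in this assay as "not active" (no number reported), with no number attached. Compound 2 `COc1ccc2[nH]c(C(=O)Cc3cccnc3)cc2c1` has no result in this assay at all, the entry reading "not determined" (no result reported). Among the measured compounds shown here, compound 3 `O=C(Cc1cccnc1)c1cc2cc(F)ccc2[nH]1` gives 24% in this assay, and that is the only number the series shows so far; it stands alone, with nothing to rank it against.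

Next is compound 4 `O=C(Cc1cccnc1)c1cc2cc(O)ccc2[nH]1`, which is to be measured in this assay. It differs from compound 3 in one place: hydroxy in place of fluoro on an aromatic carbon. For the measured compounds named here, no measured pair shows how such a change plays out in this assay, so there is no step to lean on. The expected step is a number 1 percentage points higher from compound 3 to compound 4 (within the scatter), which is taken to stay within the usual scatter of repeated measurements, with no direction claimed. For compound 4 the estimate in this assay is 25%, with a range from 5% to 45%.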

Compound 4, a percentage reported as inhibition, at one concentration (the size of the read-out at that concentration, not a potency): "not active" (no number reported)
Compound 4: no number reported; the estimate stays without a comparison.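

In this assay no step can be read between compound 3 and compound 4, as compound 4 carries no number. Nothing measured bears on this result. The compounds shown leave open how hydroxy and fluoro compare at this place on the shared core.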